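Flipping one chain stereocentre in a low-toxicity compound

The compounds below may be only part of what the source reports. "The series", "measured", "known", "first", "only" and "open" are said of these compounds alone.

- Compound 1 `Nc1nc2c(ncn2/C=C2\C[C@@H]2[C@H](O)CO)c(=O)[nH]1` in an ADME assay on HFF cells (Homo sapiens) for cytotoxicity, read by neutral red uptake; on this read-out lower numbers stand for higher toxicity in this test and higher numbers for lower toxicity in this test: > 300000 nM
- Compound 2 `Nc1ncnc2c1ncn2/C=C1/C[C@H]1[C@H](O)CO` in this assay: 206000 nM

Compound 1 has only a limit in this assay, > 300000 nM, and not an exact number. Compound 3 `Nc1nc2c(ncn2/C=C2\C[C@@H]2[C@@H](O)CO)c(=O)[nH]1` is compared with it: the two compounds have the same atoms and bonds and differ only in configuration as drawn: 1 of 3 stereo elements differ; a stereocentre at a saturated chain carbon is drawn S in compound 1 and R in compound 3. For the measured compounds named here, no measured pair here shows what such a change does, so no step beyond the usual scatter is expected in this assay, and no direction can be favoured. The estimated step is a number no higher from compound 1 to compound 3 (the limit leaves the size open). For compound 3 the expected value is 300000 nM, with an estimated range from 160000 nM to 600000 nM.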

Compound 3, half-maximal cytotoxic concentration: > 300000 nM
Compound 3: only a limit was reported; the forecaster's own chance of this, stated with the estimate: 70%; the middle value sits exactly at the limit.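

No step can be read from compound 1 to compound 3, because both carry only a limit and not an exact number: the limit of > 300000 nM in this assay, at which 2 of the 3 values shown sit.

On these data alone, whether the flipped chain stereocentre changes toxicity at all remains open.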